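The source may hold more compounds than are shown below. What is called first, only, known or untested is meant among the compounds shown, and "the series" means these compounds.

Measured so far in a functional assay on PC-3 cells (Homo sapiens) for antiproliferative activity, read by MTT assay, with a stated time of 24 h; a higher number here means a weaker inhibitor, a lower number a stronger inhibitor:
compound 1 `CCn1c(C(=O)N[C@H](C)C(=O)O)ccc1C(CC)(CC)c1ccc(OCS(=O)(=O)c2ccccc2)c(C)c1` gives 20100 nM
compound 2 `CCn1c(C(=O)NC2(C(=O)O)CC2)ccc1C(CC)(CC)c1ccc(OCS(=O)(=O)c2ccccc2)c(C)c1` gives 26300 nM

Within the data shown here, compound 2 is not separated from compound 1, the only other measured compound. Compound 3 `CCn1c(C(=O)NCCC(=O)O)ccc1C(CC)(CC)c1ccc(OCS(=O)(=O)c2ccccc2)c(C)c1` carries 2-carboxyethyl in place of 1-carboxycyclopropyl on an amide-type nitrogen when set against compound 2. Among the measured compounds shown here, the one measured step that bears on this, a 1.3-fold higher number from compound 1 to compound 2 (0.12 log units; within the scatter), also exchanges the group on that nitrogen and stays within the scatter. No step beyond the scatter is therefore expected in this assay, and a 1.1-fold lower number from compound 2 to compound 3 (0.04 log units; within the scatter) is the estimated step. Compound 3 is estimated at 24000 nM, with 10000 nM to 58000 nM as the expected range.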

Compound 3, half-maximal inhibitory concentration: 14400 nM
For compound 3 the middle estimate is 1.7-fold (0.22 log units) above the measured one, and the stated range covers the measured number.
By their numbers in this assay, from the lowest: compounds 3, 1 and 2 (each within the scatter of the next).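

In this assay 2-carboxyethyl on the amide-type nitrogen gives a 1.8-fold lower number from compound 2 to compound 3 (0.26 log units; within the scatter) in place of 1-carboxycyclopropyl, and a 1.4-fold lower number from compound 1 to compound 3 (0.14 log units; within the scatter) in place of 1-carboxyethyl. The three-membered ring can therefore be absent from this group without a step beyond the scatter, and the three groups shown on this nitrogen cannot be told apart. No supporting data are available to account for these numbers.
Still open, from the compounds shown here alone, is whether an amine in place of the carboxylic acid, or a longer chain ending in a carboxylic acid, would give a step beyond the scatter at this nitrogen.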